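Pyrimidine-thioether series: chlorobenzyl positional swap, rat artery read-out

The compounds below may be only part of what the source reports. "The series", "measured", "known", "first", "only" and "open" are said of these compounds alone.

Measured compounds:
- Compound 1, `CC1=C(C(=O)Nc2ccc(F)cc2)C(c2ccc([N+](=O)[O-])cc2)N=C(SCc2ccccc2Cl)N1`: 12.4%
- Compound 2, `CC1=C(C(=O)Nc2ccc(F)cc2)C(c2ccc([N+](=O)[O-])cc2)N=C(SCc2cccc(Cl)c2)N1`: 11.9%
- Compound 3, `CC1=C(C(=O)Nc2ccc(Br)cc2)C(c2ccc(Cl)cc2Cl)N=C(SCc2ccccc2Cl)N1`: 22.2%

All three numbers come from a functional assay on the whole organism (artery, strain albino) with Rattus norvegicus as the target, with a stated time of 180 min, at a dose of 10 mg/kg by the oral route; on this read-out lower numbers stand for less inhibition and higher numbers for more inhibition at the one dose given (going by the name of the read-out). Compound 1 and compound 2 share a core and differ only in the change (3-chlorophenyl in place of 2-chlorophenyl on a saturated chain carbon bound to a sulfur). The step of a number 0.5 percentage points lower from compound 1 to compound 2 (within the scatter) shows that this swap left the read-out essentially unchanged in that pair. Compound 3 carries a different core; the difference between the core of compound 3 and the core of compound 1 is not broken down here. Compound 3 gives the highest of the three numbers in this assay, but its gap to compound 1 lies within the scatter, and only its gap to compound 2 lies beyond it, so no ordering between compound 3 and compound 1 is claimed.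

Compound 4, `CC1=C(C(=O)Nc2ccc(Br)cc2)C(c2ccc(Cl)cc2Cl)N=C(SCc2cccc(Cl)c2)N1`, has not yet been measured. It differs from compound 3 by 3-chlorophenyl in place of 2-chlorophenyl on a saturated chain carbon bound to a sulfur, the same change as that between compound 1 and compound 2, at the same place. On the core of compound 1 this change produced a step within the scatter, so on the core of compound 3 the expected step is likewise small: compound 4 is estimated to move by a number 0.7 percentage points lower from compound 3 to compound 4 (within the scatter) in this assay, resting on the step of a number 0.5 percentage points lower from compound 1 to compound 2 (within the scatter). The starting point is the value of compound 3, 22.2%. Among the compounds with values here, compound 4 is therefore expected to give about 21.5%, with a plausible range from 12% to 31%, the width reflecting that only one earlier instance of this change is available and it sits on a different core.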

Compound 4, a percentage reported as inhibition, in the whole organism at one dose (the size of the read-out at that dose, not a potency): 11.9%
Compound 4: middle estimate off by 9.6 percentage points, on the high side, outside the stated range (below it).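

In this assay, the swap from 2-chlorobenzyl to 3-chlorobenzyl now reads a number 10.3 percentage points lower from compound 3 to compound 4 (beyond the scatter), whereas the earlier instance of the same swap stayed inside the scatter. Even so, the gap between the two steps is no larger than the scatter allows, so the data do not show that the core alters the outcome of this change, nor do they establish that the change carries over unchanged: the same change on two cores in this assay, a number 0.5 percentage points lower (within the scatter) from compound 1 to compound 2 and a number 10.3 percentage points lower (beyond the scatter) from compound 3 to compound 4, 9.8 percentage points apart, within the scatter of two such steps With only one pair on each core, at a single dose in a single read-out, the size of the step on any further core remains unsettled, and no general rule for this swap follows from these compounds.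

The compounds shown hold only a chlorophenyl on a saturated chain carbon bound to a sulfur, so it remains open how an unsubstituted phenyl, a pyridine or a longer chain ending in an amine would read at that place. The two cores also differ in more than one group, and no compound shown separates those groups, so it remains open which of them, if any, bears on the size of the step.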